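From methyl to hydroxy on the carbonyl-bearing ring

This account rests on a few compounds, and the source may have more. Where it says the series, first, only, none or still open, it means among the compounds named here.

Of the compounds shown here, three sharing one core have been tested in a functional assay on PC-3 cells (Homo sapiens) for cytotoxicity, read by MTT assay, with a stated time of 48 h; a higher number here means a weaker inhibitor, a lower number a stronger inhibitor. Compound 1, `COc1cc(-c2nnc3n2NC(c2ccco2)C(C(=O)c2ccccc2F)S3)cc(OC)c1OC`, reaches only a limit in this assay, with > 100000 nM. Compound 2, `COc1cc(-c2nnc3n2NC(c2ccco2)C(C(=O)c2ccc(Cl)cc2)S3)cc(OC)c1OC`, gives 67800 nM in this assay, and compound 3, `COc1cc(-c2nnc3n2NC(c2ccco2)C(C(=O)c2ccc(C)cc2)S3)cc(OC)c1OC`, gives 7500 nM. Among the two numbers shown, compound 3 has the lowest; the nearest is compound 2, and the step of a 9.0-fold lower number from compound 2 to compound 3 (0.96 log units; beyond the scatter) lies beyond the scatter. The step of an at least 13-fold lower number from compound 1 to compound 3 (1.12 log units; beyond the scatter) is larger still, whereas an at least 1.4-fold lower number from compound 1 to compound 2 (0.16 log units; that floor lies within the scatter) stays within the scatter.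

Compound 4, `COc1cc(-c2nnc3n2NC(c2ccco2)C(C(=O)c2ccc(O)cc2)S3)cc(OC)c1OC`, has not yet been measured. It differs from compound 3 by hydroxy in place of methyl on an aromatic carbon. Among the compounds with values here, of the measured steps, only the step from compound 2 to compound 3 touches the same aromatic carbon, and it swapped chloro for methyl; no measured pair here shows hydroxy at that place. That step was a 9.0-fold lower number from compound 2 to compound 3 (0.96 log units; beyond the scatter), so a change at this site can move the number well beyond the scatter, but its direction for hydroxy is not told by these data. Compound 4 is therefore expected to land at 20000 nM, within 5000 nM to 100000 nM. The step of a 2.7-fold higher number from compound 3 to compound 4 (0.43 log units; beyond the scatter) is estimated to mean a moderate rise in the number, with a wide range on either side.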

Compound 4, half-maximal inhibitory concentration: 38300 nM
Compound 4: the middle estimate sits 1.9-fold (0.28 log units) below what was measured; low and high end bracket the measured number.
By their numbers in this assay, from the lowest: compound 3; then compounds 4 and 2 (each within the scatter of the next). At a limit, above all of these: compound 1.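

Hydroxy at this aromatic carbon does not keep what methyl gave in this assay: a 5.1-fold higher number from compound 3 to compound 4 (0.71 log units; beyond the scatter). Within the data shown here, with a 1.8-fold lower number from compound 2 to compound 4 (0.25 log units; within the scatter), hydroxy and chloro at this carbon cannot be told apart, so among the three groups now seen there, methyl alone separates from the others, something the earlier compounds, which held no hydroxy at this place, could not show. The 4-hydroxyphenyl also separates from the 2-fluorophenyl, with an at least 2.6-fold lower number from compound 1 to compound 4 (0.41 log units; beyond the scatter), a step that gives only a floor, and compound 1 itself stands at a limit: the limit of > 100000 nM in this assay, at which 1 of the 4 values shown sits.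

What the compounds leave open is whether methyl is singular at this carbon or only the first of a series of carbon groups that lower the number, which an ethyl or a longer chain in its place would settle, while an amine there would show whether hydroxy and chloro mark a general level for groups other than methyl. A 4-fluorophenyl would also separate the identity of the fluoro group in compound 1 from its place on the ring.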